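This account rests on a few compounds, and the source may have more. Where it says the series, first, only, none or still open, it means among the compounds named here.

Of the compounds shown here, two have so far been measured in a functional assay on the whole organism (strain albino) for inhibition, with Rattus norvegicus as the target, read by paw edema, with a stated time of 1 h, at a dose of 0.28 mmol/kg by the oral route; on this read-out higher numbers stand for more inhibition at the one dose given (going by the name of the read-out) and lower numbers for less inhibition. Compound 1 `COc1ccc(-c2nnc(SCC(=O)c3ccccc3)n2-c2ccccc2)cc1OC` gives 56% in this assay. Compound 2 `COc1cc(-c2nnc(SC/C(=N/O)c3ccccc3)n2-c2ccccc2)cc(OC)c1OC` gives 61% in this assay. For the measured compounds named here, of the two numbers known, compound 2 holds the one at the top, yet its only neighbour, compound 1, falls within the usual scatter of it, so the two readings cannot be told apart. Going by the values given here, no step between measured compounds that differ in a single place has been recorded. Compound 1 and compound 2 differ from each other in two places at once.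

Compound 3 `COc1cc(-c2nnc(SCC(=O)c3ccccc3)n2-c2ccccc2)cc(OC)c1OC` has not yet been measured in this assay. It differs from compound 2 in one place: a group of 8 heavy atoms (7 carbon, 1 oxygen; one six-membered aromatic ring of carbon only) in place of a group of 9 heavy atoms (7 carbon, 1 nitrogen, 1 oxygen; one six-membered aromatic ring of carbon only), on a saturated chain carbon bound to a sulfur. The benzoyl that enters sits on a saturated chain carbon bound to a sulfur. Nothing in the measured pair isolates what this exchange does on its own. The step expected in this assay is therefore a number 3 percentage points lower from compound 2 to compound 3 (within the scatter), with no direction beyond the scatter. Compound 3 is expected to give about 58% in this assay, between 45% and 70%.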

Compound 3, a percentage reported as inhibition, in the whole organism at one dose (the size of the read-out at that dose, not a potency): 44%
For compound 3 the middle estimate is 14 percentage points above the measured one, outside the stated range (below it).
By their numbers in this assay, from the lowest: compound 3; then compounds 1 and 2 (each within the scatter of the next).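

In this assay, for the compounds shown here, compound 3 gives the first reading of this exchange on its own: benzoyl in place of the group of 9 heavy atoms, on a saturated chain carbon bound to a sulfur, comes with a number 17 percentage points lower from compound 2 to compound 3 (beyond the scatter). The same compound also isolates the other difference, methoxy in place of hydrogen on an aromatic carbon, which comes with a number 12 percentage points lower from compound 1 to compound 3 (beyond the scatter), so each of the two places that were confounded in the earlier pair now has a step of its own, beyond the scatter. Nothing given here accounts for either step.

The compounds shown leave open whether the exchange at the saturated chain carbon would give a step of similar size on the core of compound 1, and so whether the two steps are independent of each other or depend on what stands at the other place. They also leave open how an amine or a carboxylic acid on that saturated chain carbon bound to a sulfur would compare with benzoyl and with the group of 9 heavy atoms.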